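Trimming the aromatic substituent in compound 3

The source may hold more compounds than are shown below. What is called first, only, known or untested is meant among the compounds shown, and "the series" means these compounds.

Compound 2 `N=C(NS(=O)(=O)c1ccccc1C(F)(F)F)N1CCN(c2cc3c(cc2F)c(=O)c(C(=O)O)cn3C2CC2)CC1` gives 71 nM in a functional assay on A549 cells (Homo sapiens) for antiproliferative activity, read by MTT assay, with a stated time of 72 h (on this read-out higher numbers stand for weaker inhibition and lower numbers for stronger inhibition), level with compound 1 `N=C(NS(=O)(=O)c1ccccc1Cl)N1CCN(c2cc3c(cc2F)c(=O)c(C(=O)O)cn3C2CC2)CC1`, which in this assay gives 71 nM. The step of no change at the digits printed from compound 1 to compound 2 (within the scatter) shows that exchanging one group for another at this aromatic carbon left the read-out within the scatter. Compound 3 `N=C(NS(=O)(=O)c1ccccc1)N1CCN(c2cc3c(cc2F)c(=O)c(C(=O)O)cn3C2CC2)CC1` goes a step further: hydrogen in place of trifluoromethyl on an aromatic carbon. Among the measured compounds shown here, no measured step removes the group altogether, so the only evidence that bears on this change is the exchange between compound 1 and compound 2, which stayed flat. On that basis the change is expected to be small, a 1.3-fold higher number from compound 2 to compound 3 (0.13 log units; within the scatter), with no clear direction beyond the scatter, although the evidence is thin and a modest loss cannot be ruled out. Compound 3 is therefore estimated at 95 nM in this assay, with a range from 40 nM to 260 nM.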

Compound 3, half-maximal inhibitory concentration: 71 nM
For compound 3 the middle estimate is 1.3-fold (0.13 log units) above the measured one; the measured number falls inside the stated range.
By their numbers in this assay, from the lowest: compounds 1, 2 and 3 (each within the scatter of the next).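

With the substituent gone altogether, the step reads no change at the digits printed from compound 2 to compound 3 (within the scatter) in this assay, and with the chloro group gone it reads no change at the digits printed from compound 1 to compound 3 (within the scatter) on the same read-out. Among these compounds, then, the read-out does not depend on having either a trifluoromethyl or a chloro group on this aromatic carbon: the plain phenyl of compound 3 sits level with both, something the exchange of one substituent for another could not show. No measurement at hand accounts for this flat result.

On these data alone, whether the read-out stays level with groups of another kind on this carbon, such as an amine, a carboxylic acid or a methoxy group, remains open. So does whether it would hold for substituents on the other carbons of this ring, or with the shared core changed.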